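The source may hold more compounds than are shown below. What is called first, only, known or untested is meant among the compounds shown, and "the series" means these compounds.

Compound 1 `CCCCCCCCc1ccc(NC(=O)[C@@H](N)CO)cc1` — in an assay on isolated protein for inhibition of sphingosine kinase 1 (Homo sapiens), read by mobility shift assay (on this read-out lower numbers stand for stronger inhibition and higher numbers for weaker inhibition), compound 1 gives 4300 nM.
Compound 2 `CCCCCCCCc1ccc(NC(=O)[C@H](CO)NC)cc1` — in this assay compound 2 gives 2800 nM.

Only these two numbers are known. Compound 2 stands beside compound 1 with a 1.5-fold lower number from compound 1 to compound 2 (0.19 log units; within the scatter), so the two cannot be told apart on these data. Compound 3 `CCCCCCCCc1ccc(NC(=O)[C@H](N)[C@H](C)O)cc1` keeps the shared core and the same atoms as compound 2 but arranges them differently: 1-amino-2-hydroxypropyl in place of 2-hydroxy-1-(methylamino)ethyl on a carbonyl carbon. Within the data shown here, the one measured step, from compound 1 to compound 2, concerns the methyl on the amine nitrogen and was a 1.5-fold lower number from compound 1 to compound 2 (0.19 log units; within the scatter). Among the measured compounds shown here, compound 3 gives that methyl up again, which by that step should count for little, and the methyl it gains on the carbinol carbon has no measured counterpart here. A step within the scatter is therefore expected, and compound 3 is estimated at a 1.4-fold higher number from compound 2 to compound 3 (0.15 log units; within the scatter). Compound 3 is expected to give about 4000 nM in this assay, likely between 1500 nM and 12000 nM.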

Compound 3, half-maximal inhibitory concentration: 2100 nM
Estimate against measurement, compound 3: 1.9-fold (0.28 log units) above; the range from low to high includes it.
By their numbers in this assay, from the lowest: compounds 3, 2 and 1 (each within the scatter of the next, the first and the last beyond it).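

Shifting the methyl from the amine nitrogen to the carbinol carbon changes little in this assay: the rearrangement gives a 1.3-fold lower number from compound 2 to compound 3 (0.12 log units; within the scatter), so these two arrangements of the same atoms cannot be told apart. Among these compounds, the methyl on the carbinol carbon, with the amine left free, now has its own measured step, a 2.0-fold lower number from compound 1 to compound 3 (0.31 log units; beyond the scatter), the only step so far to pass the scatter, though modestly. No supporting measurement here accounts for this small gain.

The compounds shown leave open whether an ethyl or a larger group such as phenyl on the carbinol carbon would extend this step, and whether the opposite configuration at that carbon would read the same. They also leave open what a methyl on both the amine nitrogen and the carbinol carbon would give.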